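Swapping the bromide for methyl on a low-toxicity chain

This account rests on a few compounds, and the source may have more. Where it says the series, first, only, none or still open, it means among the compounds named here.

Compound 3 `O=C1N(CCCCCCCOc2ccc(Br)cc2)CCN1c1ccncc1` gives in a functional assay on cells (Homo sapiens) for cytotoxicity (on this read-out lower numbers stand for higher toxicity in this test and higher numbers for lower toxicity in this test), only a limit, > 25000 nM, so its true number is not fixed. Compound 2 `O=C1N(CCCCCCCOc2ccc(C(F)(F)F)cc2)CCN1c1ccncc1` gives 6250 nM in this assay, and compound 1 `O=C1N(CCCCCOc2ccc(C(F)(F)F)cc2)CCN1c1ccncc1` gives 12500 nM. Going by the values given here, the only measured step that touches the ring in question is an at least 4.0-fold higher number from compound 2 to compound 3 (0.60 log units; beyond the scatter); its size is known only as a lower bound set by the limit of > 25000 nM in this assay, at which 1 of the 3 values shown sits. Compound 4 `Cc1ccc(OCCCCCCN2CCN(c3ccncc3)C2=O)cc1` differs from compound 3 by 4-methylphenoxy in place of (4-bromophenoxy)methyl on a saturated chain carbon, six bonds along the chain from an amide-type nitrogen in a ring. Among the compounds with values here, no measured pair shows a methyl on that ring, so the direction is open. Compound 4 is therefore expected to remain near the limit, giving 25000 nM with a range of 8000 nM to 60000 nM. This amounts to an expected a number no higher from compound 3 to compound 4 (the limit leaves the size open), none beyond the scatter.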

Compound 4, half-maximal cytotoxic concentration: > 25000 nM
Compound 4 ended at the assay's limit; the forecaster's own chance of this, stated with the estimate: 55%; the middle value lies on the limit itself.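

Compound 3 and compound 4 both give only a limit in this assay, so the step between them cannot be read: the limit of > 25000 nM in this assay, at which 2 of the 4 values shown sit.

Going by these compounds, whether the change from compound 3 to compound 4 raises or lowers the number stays open.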